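Substituent change on the ring nitrogen: compound 2 to compound 3

The source may report more compounds than this note shows. Statements on the series, on what has been measured and on what is new or still open speak of the compounds shown alone.

Measured in a functional assay on BXPC-3 cells (Homo sapiens) for antiproliferative activity, read by sulforhodamine B assay, with a stated time of 72 h; on this read-out lower numbers stand for stronger inhibition and higher numbers for weaker inhibition:
compound 1 `CN(CCNCc1cn(-c2ccccc2Cl)nn1)CCNc1ccnc2cc(Cl)ccc12`: 11000 nM
compound 2 `CN(CCNCc1cn(Cc2ccccc2)nn1)CCNc1ccnc2cc(Cl)ccc12`: 9700 nM

Compound 2 and compound 1 sit within the scatter of each other: a 1.1-fold lower number from compound 1 to compound 2 (0.05 log units; within the scatter). Compound 3 `CN(CCNCc1cn(-c2nc3ccccc3[nH]2)nn1)CCNc1ccnc2cc(Cl)ccc12` carries 1H-benzimidazol-2-yl in place of benzyl on an aromatic nitrogen. For the measured compounds named here, the only step that bears on this position, the one from compound 1 to compound 2, changed the group on the same aromatic nitrogen and stayed within the scatter; nothing here shows a donor or acceptor at that place. No step beyond the scatter is therefore expected in this assay. Compound 3 is expected near 8500 nM, within 3000 nM to 25000 nM, an expected step of a 1.1-fold lower number from compound 2 to compound 3 (0.06 log units; within the scatter).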

Compound 3, half-maximal inhibitory concentration: 16000 nM
Compound 3: middle estimate off by 1.9-fold (0.27 log units), on the low side, within the range that was stated.
By their numbers in this assay, from the lowest: compounds 2, 1 and 3 (each within the scatter of the next).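

In this assay the change to 1H-benzimidazol-2-yl gives a 1.6-fold higher number from compound 2 to compound 3 (0.22 log units; within the scatter) and a 1.5-fold higher number from compound 1 to compound 3 (0.16 log units; within the scatter) on the same aromatic nitrogen. A group carrying a hydrogen-bond donor and a hydrogen-bond acceptor at this place therefore gives no step beyond the scatter, any more than the change between 2-chlorophenyl and benzyl did. No supporting data bear on this result. On these data alone, whether an amine, a carboxylic acid or a longer chain in place of benzyl would give a step beyond the scatter stays open. The compounds shown also do not separate the hydrogen-bond donor from the acceptor.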